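The compounds below may be only part of what the source reports. "The series", "measured", "known", "first", "only" and "open" are said of these compounds alone.

Series notes. Compound 1 `Nc1nc(N2CCN(C(=O)OCc3ccccc3)CC2)c2nc(-c3ccc(F)cc3)sc2n1`, compound 2 `Nc1nc(N2CCN(C(=O)COc3ccc(Cl)cc3)CC2)c2nc(Cc3ccc(F)cc3)sc2n1` and compound 3 `Nc1nc(N2CCN(C(=O)COc3ccc(Br)cc3)CC2)c2nc(-c3ccc(F)cc3)sc2n1` share one core and have been run in a functional assay on cells (Lymphocyte, Homo sapiens); on this read-out higher numbers stand for weaker inhibition and lower numbers for stronger inhibition. In this assay compound 1 gives 4900 nM, compound 2 gives 700 nM and compound 3 gives 380 nM. Compound 2 thus stands second highest of the three numbers, within the scatter of compound 3 and clearly apart from compound 1. Among the compounds with values here, the only single-point step known is a 13-fold lower number from compound 1 to compound 3 (1.11 log units; beyond the scatter), a change on the carbonyl side. Compound 4 `Nc1nc(N2CCN(C(=O)COc3ccc(Cl)cc3)CC2)c2nc(CCCc3ccc(F)cc3)sc2n1` differs from compound 2 elsewhere: 2-(4-fluorophenyl)ethyl in place of 4-fluorophenyl on a saturated chain carbon bound to an aromatic carbon. Within the data shown here, no measured step touches that chain, and compound 2 and compound 3 differ in two places at once. The expectation is a step of no more than the scatter, a 1.3-fold higher number from compound 2 to compound 4 (0.11 log units; within the scatter). Compound 4 is expected at 900 nM, range 300 nM to 2700 nM.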

Compound 4, half-maximal inhibitory concentration: 960 nM
The estimate for compound 4 lay 1.1-fold (0.03 log units) below the measured number, within the range that was stated.
By their numbers in this assay, from the lowest: compounds 3, 2 and 4 (each within the scatter of the next, the first and the last beyond it); then compound 1.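

Within the data shown here, this is the first step read at this position: on a saturated chain carbon bound to an aromatic carbon, 2-(4-fluorophenyl)ethyl in place of 4-fluorophenyl gives a 1.4-fold higher number from compound 2 to compound 4 (0.14 log units; within the scatter) in this assay and leaves the two compounds within the scatter. For this pair, the longer group is accommodated with no change that can be read. No measurement at hand bears on why. 

Open, on these data alone, is whether a longer chain, or an amine or a carboxylic acid at the end of the chain, would stay within the scatter of compound 2.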